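Moving the methoxy group: 4-methoxyphenoxy to 2-methoxyphenoxy

The source may report more compounds than this note shows. Statements on the series, on what has been measured and on what is new or still open speak of the compounds shown alone.

Compound 1 `COc1ccc(OCC(=O)N2CCN(C(c3ccc(F)cc3)c3ccc(F)cc3)CC2)cc1` and compound 2 `COc1ccc(OCC(=O)N2CCN(C(c3ccc(Br)cc3)c3ccc(Br)cc3)CC2)cc1` share a common core; the difference between the two cores is not broken down here. In a functional assay on PC-12 cells (Rattus norvegicus) for cytotoxicity, read by MTT assay, with a stated time of 24 h, tested at 0.1 uM (a higher number here means a stronger effect of the compound at the concentration tested, a lower number a weaker effect), compound 1 gives 3.1%, and in this assay compound 2 gives 3.52%; the two values lie within the usual scatter of each other. Compound 3 `COc1ccccc1OCC(=O)N1CCN(C(c2ccc(F)cc2)c2ccc(F)cc2)CC1` carries the change 2-methoxyphenyl in place of 4-methoxyphenyl on an oxygen on a saturated carbon relative to compound 1, and in this assay compound 3 gives 32%, a step of a number 28.9 percentage points higher from compound 1 to compound 3 (beyond the scatter).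

Compound 4 `COc1ccccc1OCC(=O)N1CCN(C(c2ccc(Br)cc2)c2ccc(Br)cc2)CC1` has not yet been measured. It differs from compound 2 by 2-methoxyphenyl in place of 4-methoxyphenyl on an oxygen on a saturated carbon, the same change as from compound 1 to compound 3, at the same place. For the measured compounds named here, the expected step from compound 2 to compound 4 in this assay is a number 24.5 percentage points higher from compound 2 to compound 4 (beyond the scatter), resting on the single precedent a number 28.9 percentage points higher from compound 1 to compound 3 (beyond the scatter) from compound 1 to compound 3; with only one example the uncertainty is wide. Compound 4 is therefore estimated at 28%, expected to fall between 8% and 45%.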

Compound 4, a percentage reported as activity, at one concentration (the size of the read-out at that concentration, not a potency): 45.5%
For compound 4 the middle estimate is 17.5 percentage points below the measured one; measured number above the stated range.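

In this assay, 2-methoxyphenyl in place of 4-methoxyphenyl on an oxygen on a saturated carbon gives a step of a number 42 percentage points higher from compound 2 to compound 4 (beyond the scatter). Set beside the earlier step, the change carries from one core to the other in direction and, within the scatter, in size: the same change on two cores in this assay, a number 28.9 percentage points higher (beyond the scatter) from compound 1 to compound 3 and a number 42 percentage points higher (beyond the scatter) from compound 2 to compound 4, 13.1 percentage points apart, within the scatter of two such steps This rests on two cores only, so it supports transfer between these two and does not show that the step would hold on any other core, and as a read-out at one concentration it says nothing about potency or about why the change raises the number.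

The compounds shown leave open where 3-methoxyphenyl would fall relative to the 2-methoxyphenyl and 4-methoxyphenyl pairs. Also open, going by these compounds, is whether the step survives when the methoxy group gives way to an ethoxy group, a dimethylamino group or a carboxylic acid.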